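The source may report more compounds than this note shows. Statements on the series, on what has been measured and on what is new or still open speak of the compounds shown alone.

Working notes on the series.

Within the data shown here, the three measured members share one core. Compound 1 `CC(C)c1onc(-c2c(Cl)cccc2Cl)c1COc1ccc(N(C)Cc2cccc(C(=O)O)c2)c(C(F)(F)F)n1` gives 12 nM in an assay on isolated protein for agonist activity at Bile acid receptor (Homo sapiens), read by FRET; on this read-out lower numbers stand for an effect already at smaller amounts and higher numbers for an effect only at larger amounts of compound. Compound 2 `CC(C)c1onc(-c2c(Cl)cccc2Cl)c1COc1ccc(N(C)Cc2ccc(C(=O)NS(C)(=O)=O)cc2)c(C(F)(F)F)n1` differs from compound 1 at two places at once. In this assay compound 2 gives 40 nM. Compound 3 `CN(Cc1cccc(C(=O)O)c1)c1ccc(OCc2c(-c3c(Cl)cccc3Cl)noc2C2CC2)nc1C(F)(F)F` gives 3 nM in this assay and so holds the lowest of the three numbers; the nearest is compound 1 and the furthest is compound 2. Among the measured compounds shown here, the only single-point step among them is a 4.0-fold lower number from compound 1 to compound 3 (0.60 log units; beyond the scatter).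

Compound 4 `CC(Oc1cccc(C(=O)O)c1)c1ccc(OCc2c(-c3c(Cl)cccc3Cl)noc2C2CC2)nc1C(F)(F)F` is the next member. The change from compound 3 is 1-(3-carboxyphenoxy)ethyl in place of (3-carboxybenzyl)(methyl)amino on an aromatic carbon. For the measured compounds named here, no measured step touches this part of the molecule: the step from compound 1 to compound 3 sits on the other side of the core, and compound 2 differs from compound 1 at two places at once, so its number cannot be split into single contributions. The expectation for compound 4 therefore rests on analogy only, with nothing in the measured set to anchor it, and a step of a 3.3-fold higher number from compound 3 to compound 4 (0.52 log units; beyond the scatter) is estimated as the most likely outcome, with the true value possibly lying within the scatter of compound 3. For compound 4 the value in this assay is estimated at 10 nM, between 3 nM and 40 nM.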

Compound 4, half-maximal effective concentration: 155 nM
Compound 4: the middle estimate sits 16-fold (1.19 log units) below what was measured, outside the stated range (above it).
By their numbers in this assay, from the lowest: compound 3; then compound 1; then compound 2; then compound 4.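

In this assay, among these compounds, the exchange at this position gives a 52-fold higher number from compound 3 to compound 4 (1.71 log units; beyond the scatter), a much larger step than a 4.0-fold lower number from compound 1 to compound 3 (0.60 log units; beyond the scatter), so the series so far responds more strongly here than to the cyclopropyl for isopropyl change. The leaving (3-carboxybenzyl)(methyl)amino and the entering 1-(3-carboxyphenoxy)ethyl match in heavy atom count, in their six-membered aromatic ring of carbon only, in hydrogen-bond donors and acceptors and in net charge, and they differ in composition only in one nitrogen against one further oxygen, so these counts alone do not predict how the number moves at this position. Nothing available bears on the reason for this step.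

The compounds shown leave open whether the higher number goes with losing the amine nitrogen, gaining the ether oxygen or moving the methyl onto a carbon, since all three change together in this one step. A linker with an unbranched methylene chain in place of the 1-substituted ethyl, or one keeping the amine nitrogen while carrying an ether oxygen towards the carboxylic acid ring, would separate these contributions.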